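Configuration changes in a series at the assay limit

The compounds below may be only part of what the source reports. "The series", "measured", "known", "first", "only" and "open" are said of these compounds alone.

Measured in a functional assay on HCT-116 cells (Homo sapiens) for cytotoxicity, read by MTT assay, with a stated time of 72 h; on this read-out lower numbers stand for stronger inhibition and higher numbers for weaker inhibition:
- compound 1 `C=C(C)[C@@H]1CC[C@](C)(O)[C@H]1/C=C/C(C)=C/[C@@H]1C[C@@]2([C@H](OC)O1)[C@H](CCCO)/C(=C(/C)C=O)CC[C@]2(C)O`: > 10000 nM (a limit)
- compound 2 `C=C(C)[C@@H]1CC[C@](C)(O)[C@H]1/C=C/C(C)=C/[C@@H]1C[C@@]2([C@H](OC)O1)[C@H](CCCO)/C(=C(\C)C=O)CC[C@]2(C)O`: > 10000 nM (a limit)

Compound 2 has only a limit, > 10000 nM, and no number places it in the series. The same holds for the whole measured set, with the limit of > 10000 nM in this assay, at which 2 of the 2 values shown sit.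

Compound 3 `C=C(C)[C@H]1CC[C@@](C)(O)[C@@H]1/C=C/C(C)=C/[C@@H]1C[C@@]2([C@H](OC)O1)[C@H](CCCO)/C(=C(/C)C=O)CC[C@]2(C)O` has not yet been measured. The change from compound 2 is this: the two compounds have the same atoms and bonds and differ only in configuration as drawn: 4 of 11 stereo elements differ; a stereocentre at a saturated ring carbon is drawn R in compound 2 and S in compound 3; a stereocentre at a saturated ring carbon is drawn S in compound 2 and R in compound 3; a stereocentre at a saturated ring carbon is drawn S in compound 2 and R in compound 3; a double bond is drawn E in compound 2 and Z in compound 3.

Among the measured compounds shown here, the one measured step, a step that the two limits leave unreadable from compound 1 to compound 2, is also a change of double bond configuration, and it comes with the fact that compounds 1 and 2 differ only in the configuration as drawn. Its size cannot be read, so it gives no measure for the double bond part of the new change. For the measured compounds named here, no measured step covers the three stereocentres at saturated ring carbons.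

With no measured potency on either side, no clear gain is expected in this assay, and a further limit is the likeliest report for compound 3. The expected change, which is only loosely defined, is a step that the limit leaves unreadable from compound 2 to compound 3.

For compound 3 the estimated value is 15000 nM, with an expected range from 6000 nM to 40000 nM.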

Compound 3, half-maximal inhibitory concentration: > 10000 nM
Compound 3 ended at the assay's limit; the forecaster's own chance of this, stated with the estimate: 80%; the middle value lies beyond the limit too.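

In this assay compound 3 gives > 10000 nM, which is a limit and not a number. The steps from compound 1 and compound 2 to compound 3 cannot be read, as all three compounds sit at a limit. The compounds shown leave open whether the double bond configuration or the three stereocentres at saturated ring carbons have any effect on potency in this assay.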